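The compounds below may be only part of what the source reports. "The series", "measured", "known", "first", "only" and "open" are said of these compounds alone.

Of the compounds shown here, three sharing one core have been tested in a functional assay on U-87MG ATCC cells (Homo sapiens) for cytotoxicity, read by MTT assay, with a stated time of 72 h; on this read-out higher numbers stand for weaker inhibition and lower numbers for stronger inhibition. Compound 1 `CN(C)CCn1cnnc1-c1cc(Oc2ccc(NC(=O)N/N=C/c3ccc(F)cc3F)cc2F)ccn1` gives 1900 nM, compound 2 `COc1cc(/C=N/NC(=O)Nc2ccc(Oc3ccnc(-c4nncn4CCN(C)C)c3)c(F)c2)cc(OC)c1OC` gives 22500 nM, and compound 3 `CN(C)CCn1cnnc1-c1cc(Oc2ccc(NC(=O)N/N=C/c3c(O)ccc4ccccc34)cc2F)ccn1` gives 620 nM, the lowest of the three. Each differs only in the group on the carbon with a double bond to nitrogen, and that group matters: a 3.1-fold lower number from compound 1 to compound 3 (0.49 log units; beyond the scatter) and a 36-fold lower number from compound 2 to compound 3 (1.56 log units; beyond the scatter). Compound 4 `Cc1cc(/C=N/NC(=O)Nc2ccc(Oc3ccnc(-c4nncn4CCN(C)C)c3)c(F)c2)cc(C)c1O` alters the same position: 4-hydroxy-3,5-dimethylphenyl in place of 2-hydroxynaphthalen-1-yl on a carbon with a double bond to nitrogen. Since both earlier changes at this position moved the number well beyond the scatter, and compound 3 holds the best number, a step upward in this assay is expected from this replacement of two rings by one: a 4.8-fold higher number from compound 3 to compound 4 (0.68 log units; beyond the scatter). The estimate for compound 4 is 3000 nM, with a range from 800 nM to 12000 nM.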

Compound 4, half-maximal inhibitory concentration: 7710 nM
Beside the measured number, compound 4's estimate is 2.6-fold (0.41 log units) below it, within the range that was stated.
By their numbers in this assay, from the lowest: compound 3; then compound 1; then compound 4; then compound 2.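

A hydroxyl on the ring does not by itself keep the number low: with 4-hydroxy-3,5-dimethylphenyl in place of 2-hydroxynaphthalen-1-yl there is a 12-fold higher number from compound 3 to compound 4 (1.09 log units; beyond the scatter). Among the single rings, the new group falls in the middle, with a 4.1-fold higher number from compound 1 to compound 4 (0.61 log units; beyond the scatter) against 2,4-difluorophenyl, which carries no hydroxyl, and a 2.9-fold lower number from compound 2 to compound 4 (0.47 log units; beyond the scatter) against 3,4,5-trimethoxyphenyl. Nothing available here explains these gaps.

Open, from the compounds shown here alone, is whether the second ring or the place of the hydroxyl counts for more; a plain naphthalen-1-yl or a 2-hydroxyphenyl would separate the two. Going by these compounds, how an amine on the ring would fare also remains open.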